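Removing the pyridin-3-yl group from compound 2

The source may hold more compounds than are shown below. What is called first, only, known or untested is meant among the compounds shown, and "the series" means these compounds.

Compound 1 `O=C(NO)c1cccc(/C=C/c2ccnc(-c3ccccc3O)c2)c1`: 2810 nM
Compound 2 `O=C(NO)c1ccc(/C=C/c2ccnc(-c3cccnc3)c2)cc1`: 4550 nM
Compound 3 `O=C(NO)c1ccc(/C=C/c2cc(-c3ccc(C(F)(F)F)cc3)ncc2F)cc1`: > 10000 nM

In a functional assay on MGC-803 cells (Homo sapiens) for antiproliferative activity, read by CellTiter-Glo, with a stated time of 72 h (on this read-out lower numbers stand for stronger inhibition and higher numbers for weaker inhibition), compound 2 at 4550 nM and compound 1 at 2810 nM lie within the usual scatter of each other. For compound 3 the reading > 10000 nM is a limit of the assay and not a number.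

Compound 4 `O=C(NO)c1ccc(/C=C/c2ccncc2)cc1` has not been measured yet. The change from compound 2 to compound 4 (hydrogen in place of pyridin-3-yl on an aromatic carbon) puts hydrogen in place of pyridin-3-yl on an aromatic carbon. Going by the values given here, no measured pair shows this change, so only a small move toward weaker inhibition in this assay is expected, perhaps none beyond the scatter. The expected step (a 1.3-fold higher number from compound 2 to compound 4 (0.12 log units; within the scatter)) is modest. Compound 4 is estimated at 6000 nM with a range from 2000 nM to 12000 nM and could also end at the limit of the assay.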

Compound 4, half-maximal inhibitory concentration: 3930 nM
Compound 4: middle estimate off by 1.5-fold (0.18 log units), on the high side; measured number inside the range.
By their numbers in this assay, from the lowest: compounds 1, 4 and 2 (each within the scatter of the next). At a limit, above all of these: compound 3.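

In this assay putting hydrogen in place of pyridin-3-yl next to the ring nitrogen gives a 1.2-fold lower number from compound 2 to compound 4 (0.06 log units; within the scatter) and so no change that can be told from the scatter. Going by these compounds alone, no earlier pair showed this: the whole pyridin-3-yl group can leave this position without a measurable change in this read-out. Nothing measured here gives a reason for this result.

Still open, on these data alone, is whether a small amine, a methoxy group or a longer chain at this position would move the number beyond the scatter.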